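This account rests on a few compounds, and the source may have more. Where it says the series, first, only, none or still open, it means among the compounds named here.

Two compounds of this series have been run in an ADME assay on 184B5 cells (Homo sapiens) for cytotoxicity, read by MTT assay, with a stated time of 72 h; a higher number here means a weaker inhibitor of growth, a lower number a stronger inhibitor of growth. Compound 1 `CSc1nc(NCCCc2ccccc2)c2ccccc2n1` reaches only the limit of the measurement: in this assay compound 1 gives > 100000 nM, which is a limit and not a number. Compound 2 `Sc1nc(NCc2ccccc2)c2ccccc2n1` stands the same way: in this assay compound 2 gives > 100000 nM, again a limit of the assay rather than a measured concentration. Within the data shown here, both values sit at the limit of > 100000 nM in this assay, at which 2 of the 2 values shown sit, so compound 2 stands on the limit itself, and there is no step between measured compounds to weigh. Compound 3 `C[Se]c1nc(NCc2ccccc2)c2ccccc2n1` is not yet measured. It differs from compound 2 by a group of 2 heavy atoms (1 carbon, 1 selenium; no ring) in place of one sulfur atom, on an aromatic carbon — in words, a group of 2 heavy atoms (1 carbon, 1 selenium; no ring) in place of one sulfur atom, on an aromatic carbon. With both measured values at the limit, no change beyond the scatter is expected, and the estimated step is a number no higher from compound 2 to compound 3 (the limit leaves the size open). Compound 3 is accordingly expected to give about 100000 nM in this assay, in a range from 40000 nM to 300000 nM, most likely reported again only as a limit.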

Compound 3, concentration for total growth inhibition: 12400 nM
For compound 3 the middle estimate is 8.1-fold (0.91 log units) above the measured one, and the stated range ends above it.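

In this assay, replacing the sulfanyl group with the group of one carbon and one selenium gives an at least 8.0-fold lower number from compound 2 to compound 3 (0.90 log units; beyond the scatter), so this change on the aromatic carbon between two ring nitrogen atoms moves the read-out beyond the usual scatter. Compound 2 gives > 100000 nM, which is a limit and not a number, so the step has a floor but no known size. Compound 3 is the only compound shown with a value off the limit, which makes this position the first place in the series where a structural change can be read, while the earlier values offered no such reading: the limit of > 100000 nM in this assay, at which 2 of the 3 values shown sit.

The carbon and the selenium enter together, so the compounds shown do not separate the contribution of either atom, and a selenium-bearing ethyl group or a methylsulfanyl group on the same benzylamino core would be needed to do so. On these data alone, whether an amine or a longer chain at this position would keep, deepen or lose the step also remains open, as does whether the step holds with the longer phenylpropyl chain of compound 1.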